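An Amino Group on the Phenyl Ring of Compound 3

The compounds below may be only part of what the source reports. "The series", "measured", "known", "first", "only" and "open" are said of these compounds alone.

- compound 1 `CCn1c(C(F)(F)F)nc2cc(Cl)c(Cl)cc21`: 72900 nM
- compound 2 `FC(F)(F)c1nc2cc(Cl)c(Cl)cc2n1CC1CC1`: 60200 nM
- compound 3 `FC(F)(F)c1nc2cc(Cl)c(Cl)cc2n1Cc1ccccc1`: 8700 nM

All three values come from a functional assay on MCF7 cells (Homo sapiens) for cytotoxicity, read by MTT assay, with a stated time of 48 h; on this read-out lower numbers stand for stronger inhibition of growth and higher numbers for weaker inhibition of growth. Compound 3, at 8700 nM, gives the lowest number of the three, and its steps to both others lie beyond the scatter.

Compound 4 `Nc1ccccc1Cn1c(C(F)(F)F)nc2cc(Cl)c(Cl)cc21` keeps everything in compound 3 except for one change, phenyl to 2-aminophenyl: amino in place of hydrogen on an aromatic carbon. The new amino group sits ortho to a large group.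

The measured steps bear on this change only indirectly. All of them swap the group on the saturated chain carbon bound to an aromatic nitrogen. The modest steps are an 8.4-fold lower number from compound 1 to compound 3 (0.92 log units; beyond the scatter) and a 6.9-fold lower number from compound 2 to compound 3 (0.84 log units; beyond the scatter), while a 1.2-fold lower number from compound 1 to compound 2 (0.08 log units; within the scatter) stays within the scatter. These steps show that the number in this assay can move with a change in this part of the molecule, but none of them places a substituent on the phenyl ring. The data therefore give no direction for the amino group, and no step beyond the scatter is expected. The estimated change is a 1.1-fold lower number from compound 3 to compound 4 (0.04 log units; within the scatter), with wide uncertainty. For compound 4 the expected value is 8000 nM, within an estimated range from 2500 nM to 25000 nM.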

Compound 4, concentration for 50% growth inhibition: 55600 nM
Compound 4: the middle estimate sits 7.0-fold (0.84 log units) below what was measured; measured number above the stated range.
By their numbers in this assay, from the lowest: compound 3; then compounds 4, 2 and 1 (each within the scatter of the next).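

In this assay, the phenyl ring of compound 3 turns out not to be indifferent to substitution: amino in place of hydrogen on an aromatic carbon, ortho to a large group, gives a 6.4-fold higher number from compound 3 to compound 4 (0.81 log units; beyond the scatter) and so moves the number by a modest step, where the earlier compounds had shown such steps only for changes of the group on the saturated chain carbon. The advantage that compound 3 held over the two smaller groups disappears with this one change, as seen in a 1.1-fold lower number from compound 2 to compound 4 (0.03 log units; within the scatter) and in a 1.3-fold lower number from compound 1 to compound 4 (0.12 log units; within the scatter), both within the scatter, so a phenyl ring on that carbon does not by itself bring the lower number. Nothing available accounts for this loss.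

The compounds shown leave open whether the rise belongs to the amino group as such or to its place, since they hold no amino group elsewhere on the phenyl ring. They also do not tell whether a hydroxyl, a methyl, a chlorine or an acetamide at the same carbon would give a similar number.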